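The source may report more compounds than this note shows. Statements on the series, on what has been measured and on what is new or still open speak of the compounds shown alone.

Compound 1, `N#CCCN(Cc1cccs1)S(=O)(=O)c1ccc(F)cc1`, was tested in an ADME assay on MDCK cells (Canis lupus familiaris) for cytotoxicity, read by MTT assay, with a stated time of 24 h; on this read-out lower numbers stand for higher toxicity in this test and higher numbers for lower toxicity in this test. In this assay compound 1 gives only a limit of the assay, > 205000 nM, not a number. Compound 2, `N#CCCN(Cc1cccs1)S(=O)(=O)c1ccc(Cl)cc1`, is its closest measured relative, carrying chloro in place of fluoro on an aromatic carbon. In this assay compound 2 likewise gives only a limit, > 195000 nM. Among the compounds with values here, the one measured step, a step that the two limits leave unreadable from compound 1 to compound 2, therefore cannot be sized, since both values rest at a ceiling of the test: the limit of > 195000 nM in this assay, at which 1 of the 2 values shown sits, and (the limit of > 205000 nM in this assay, at which 1 of the 2 values shown sits). Compound 3, `CC(=O)c1ccc(S(=O)(=O)N(CCC#N)Cc2cccs2)cc1`, is the compound still to be measured. It differs from compound 1 by acetyl in place of fluoro on an aromatic carbon. No measured step covers this exchange, and the only step shown is unreadable, so nothing points toward a move beyond the scatter in this assay in either direction. The step is expected to be an at least 1.0-fold lower number from compound 1 to compound 3 (0.01 log units; that floor lies within the scatter). Compound 3 is thus expected to give about 200000 nM, within 70000 nM to 400000 nM, in this assay, quite possibly again only as a limit.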

Compound 3, half-maximal cytotoxic concentration: > 191000 nM
Compound 3 gave a limit, no number (the forecaster's own chance of this, stated with the estimate: 70%); the middle value does not contradict the limit.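

Within the data shown here, no step between compound 1, compound 2 and compound 3 can be read in this assay: each gives only a limit, not a number. The compounds shown leave open whether fluoro, chloro and acetyl on this aromatic carbon differ at all in this assay.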